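Series notes: the step from compound 3 to compound 4

The source may hold more compounds than are shown below. What is called first, only, known or untested is meant among the compounds shown, and "the series" means these compounds.

Compound 1 `CC(=O)N1CCc2nc(C#Cc3ccccc3)sc2C1` in an assay on HEK293 cells for negative allosteric modulation of metabotropic glutamate receptor 5 (Homo sapiens), read by FLIPR, with a stated time of 1 h (a higher number here means a weaker inhibitor, a lower number a stronger inhibitor), gives 90 nM. Compound 2 `O=C(C1CCC(F)(F)CC1)N1CCc2nc(C#Cc3ccccc3)sc2C1` in this assay gives only a limit, > 10000 nM. Compound 3 `CC1CCC(C(=O)N2CCc3nc(C#Cc4ccccc4)sc3C2)CC1` in this assay likewise gives only a limit, > 10000 nM. Compound 3 thus stands at the limit of > 10000 nM in this assay, at which 2 of the 3 values shown sit, and the step that the two limits leave unreadable from compound 2 to compound 3 cannot be read. The larger acyl groups weaken inhibition sharply: an at least 110-fold higher number from compound 1 to compound 2 (2.04 log units; beyond the scatter) and an at least 110-fold higher number from compound 1 to compound 3 (2.04 log units; beyond the scatter). Compound 4 `CC1CCCC(C(=O)N2CCc3nc(C#Cc4ccccc4)sc3C2)C1` carries the change (3-methylcyclohexyl in place of 4-methylcyclohexyl on a carbonyl carbon). Within the data shown here, no measured step separates two cyclohexyl isomers in a readable way; both cyclohexyl analogues gave the same weak result, so compound 4 is expected to stay equally weak, with an expected step that the limit leaves unreadable from compound 3 to compound 4 not beyond the scatter. The estimate for compound 4 in this assay is 15000 nM, range 4000 nM to 60000 nM.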

Compound 4, half-maximal inhibitory concentration: > 10000 nM
Compound 4 gave a limit, no number; the forecaster's own chance of this, stated with the estimate: 80%; the middle value does not contradict the limit.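

Moving the ring methyl, with 3-methylcyclohexyl in place of 4-methylcyclohexyl, does not bring back inhibition in this assay; against the methyl of compound 1, this group gives an at least 110-fold higher number from compound 1 to compound 4 (2.04 log units; beyond the scatter). All three cyclohexyl analogues now give only a limit, while compound 1 alone gives a number: the limit of > 10000 nM in this assay, at which 3 of the 4 values shown sit. The steps among compounds 2, 3 and 4 cannot be read, so any effect of moving the methyl stays hidden.

From the compounds shown here alone, what an ethyl or cyclopropyl group on the carbonyl carbon gives remains open.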